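Isopropyl for vinyl on the carbonyl of compound 2

The compounds below may be only part of what the source reports. "The series", "measured", "known", "first", "only" and "open" are said of these compounds alone.

Values in an ADME assay on BaF3 cells (Mus musculus) for cytotoxicity, read by CellTiter-Glo and CCK-8 assay, with a stated time of 72 h; on this read-out lower numbers stand for stronger inhibition of growth and higher numbers for weaker inhibition of growth:
Compound 1 `CCC(=O)Nc1ccc(C(=O)Nc2ccc(C)c(Nc3nccc(-c4cccnc4)n3)c2)cc1` gives > 10000 nM, a limit of the assay and not a number.
Compound 2 `C=CC(=O)N(CCN(C)C)Cc1ccc(C(=O)Nc2ccc(C)c(Nc3nccc(-c4cccnc4)n3)c2)cc1` gives > 10000 nM, likewise a limit of the assay.

Both measured values sit at the limit of > 10000 nM in this assay, at which 2 of the 2 values shown sit, so compound 2 stands at the limit, and compound 1 stands there too; neither can be placed against the other. Within the data shown here, the only step among the measured compounds, a step that the two limits leave unreadable from compound 1 to compound 2, is not readable in size for that reason, and it concerns a different part of the molecule.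

Compound 3 `Cc1ccc(NC(=O)c2ccc(CN(CCN(C)C)C(=O)C(C)C)cc2)cc1Nc1nccc(-c2cccnc2)n1` differs from compound 2 by isopropyl in place of vinyl on a carbonyl carbon. Among the measured compounds shown here, no measured step bears on this change, and none gives a size for it. With compound 2 at the limit and nothing pointing to a readable gain, the working expectation is that compound 3 will again sit at or beyond the limit of this assay, with the step from compound 2 expected to be none beyond the scatter or unreadable.

Compound 3 is expected to give 15000 nM, in a range from 5000 nM to 50000 nM. The step this estimate means is expected to be a step that the limit leaves unreadable from compound 2 to compound 3, resting on compound 2 sitting at the limit of > 10000 nM in this assay, at which 2 of the 2 values shown sit.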

Compound 3, concentration for 50% growth inhibition: > 10000 nM
Compound 3 gave a limit, no number; the forecaster's own chance of this, stated with the estimate: 85%; the middle value does not contradict the limit.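

No step can be read among compound 1, compound 2 and compound 3 in this assay, because all three values are limits of the assay and not numbers: the limit of > 10000 nM in this assay, at which 3 of the 3 values shown sit.

The compounds shown leave open how isopropylcarbonyl and vinylcarbonyl compare, and whether any of these groups on the shared core gives a readable inhibition of growth.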